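The source may hold more compounds than are shown below. What is called first, only, known or untested is meant among the compounds shown, and "the series" means these compounds.

In a functional assay on RPMI 8402 cells (Homo sapiens) for cytotoxicity (on this read-out higher numbers stand for weaker inhibition and lower numbers for stronger inhibition), compound 1 (`N#Cc1ccc2[nH]c(-c3ccc4[nH]c(-c5ccccc5)nc4c3)nc2c1`) gives > 25000 nM, which is a limit of the assay and not a number. Compound 2 (`Cc1ccccc1-c1nc2cc(-c3nc4cc(C#N)ccc4[nH]3)ccc2[nH]1`) gives 1200 nM and compound 3 (`Cc1ccc(-c2nc3cc(-c4nc5cc(C#N)ccc5[nH]4)ccc3[nH]2)cc1`) gives 570 nM, so compound 3 holds the lower of the two actual numbers in this assay.

Methyl in place of hydrogen on an aromatic carbon accounts for an at least 20-fold lower number from compound 1 to compound 2 (1.31 log units; beyond the scatter) and for an at least 43-fold lower number from compound 1 to compound 3 (1.64 log units; beyond the scatter), both large and both measured from a limit. Exchanging 2-methylphenyl for 4-methylphenyl accounts for a 2.1-fold lower number from compound 2 to compound 3 (0.32 log units; beyond the scatter), a modest step.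

Compound 4 (`N#Cc1ccc2[nH]c(-c3ccc4[nH]c(-c5ccc6ccccc6c5)nc4c3)nc2c1`) carries naphthalen-2-yl in place of 4-methylphenyl on an aromatic carbon. For the measured compounds named here, no measured step makes this exchange directly. The closest guides are an at least 43-fold lower number from compound 1 to compound 3 (1.64 log units; beyond the scatter), which shows how much the assay can respond at this place, and a 2.1-fold lower number from compound 2 to compound 3 (0.32 log units; beyond the scatter), which shows a much smaller response between two substituted groups. Compound 4 keeps a substituted group of this kind, so only a small step is expected in this assay, with no firm direction and quite possibly none beyond the scatter. The expected change is a 1.1-fold lower number from compound 3 to compound 4 (0.06 log units; within the scatter). For compound 4 the estimated value is 500 nM, with an expected range from 120 nM to 3000 nM.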

Compound 4, half-maximal inhibitory concentration: 130 nM
The estimate for compound 4 lay 3.8-fold (0.59 log units) above the measured number, and the stated range covers the measured number.
By their numbers in this assay, from the lowest: compound 4; then compound 3; then compound 2. At a limit, above all of these: compound 1.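

Working notes on the aromatic carbon between two ring nitrogen atoms: in this assay, naphthalen-2-yl gives a 4.4-fold lower number from compound 3 to compound 4 (0.64 log units; beyond the scatter) and a 9.2-fold lower number from compound 2 to compound 4 (0.97 log units; beyond the scatter), both larger steps than the one between the two methylphenyl groups, a 2.1-fold lower number from compound 2 to compound 3 (0.32 log units; beyond the scatter). The earlier compounds shown here showed only that a methyl on the phenyl group matters here; compound 4 now shows that this place also accepts a group with 2 six-membered aromatic rings of carbon only, and that the number keeps falling, so compound 4 stands lowest among the compounds with actual numbers. The widest span, an at least 190-fold lower number from compound 1 to compound 4 (2.28 log units; beyond the scatter), starts from compound 1, whose value is a limit of the assay and not a number, so its true size stays unknown: the limit of > 25000 nM in this assay, at which 1 of the 4 values shown sits.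

In compound 4 the second aromatic ring and the larger carbon count enter together, so the compounds shown do not tell which of the two goes with the lower number, nor how naphthalen-1-yl would compare with naphthalen-2-yl. Going by these compounds, every group at this place is carbon only, so what an amine or a carboxylic acid on the aromatic ring would do here remains open.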